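This account rests on a few compounds, and the source may have more. Where it says the series, first, only, none or still open, it means among the compounds named here.

Measured so far in a functional assay on the whole organism (blood) with Rattus norvegicus as the target, with stated times of 24 h and 1 h, at a dose of 5 mg/kg by the intraperitoneal route; on this read-out lower numbers stand for a weaker effect and higher numbers for a stronger effect at the one dose given:
Compound 1 `O=C(NC1CCCCC1)NS(=O)(=O)N1CCC(CCNC(=O)c2csnn2)CC1` gives 19% in this assay.
Compound 2 `COc1ncccc1C(=O)NCCC1CCN(S(=O)(=O)NC(=O)NC2CCCCC2)CC1` gives 33% in this assay.

Compound 2 holds the higher of the two numbers shown, the only measured step being a number 14 percentage points higher from compound 1 to compound 2 (beyond the scatter). Compound 3 `O=C(NC1CCCCC1)NS(=O)(=O)N1CCC(CCNC(=O)c2cccc3cccnc23)CC1` differs from compound 2 by quinolin-8-yl in place of 2-methoxypyridin-3-yl on a carbonyl carbon. That one step, 2-methoxypyridin-3-yl in place of 1,2,3-thiadiazol-4-yl on the same carbonyl carbon, was modest and says nothing direct about quinolin-8-yl at that place. In this assay no step beyond the scatter is therefore expected for compound 3, the expected change being no change at the digits printed from compound 2 to compound 3 (within the scatter). Compound 3 is estimated at 33%, in the range 15% to 50%.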

Compound 3, a percentage reported as activity, at one dose (the size of the read-out at that dose, not a potency): 37%
Beside the measured number, compound 3's estimate is 4 percentage points below it, within the range that was stated.
By their numbers in this assay, from the lowest: compound 1; then compounds 2 and 3 (each within the scatter of the next).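

In this assay quinolin-8-yl on the carbonyl carbon gives a number 4 percentage points higher from compound 2 to compound 3 (within the scatter), so this larger group and 2-methoxypyridin-3-yl are not told apart at this position. Set against 1,2,3-thiadiazol-4-yl, quinolin-8-yl gives a number 18 percentage points higher from compound 1 to compound 3 (beyond the scatter), so both six-membered aromatic replacements now read beyond the scatter from compound 1. No supporting data are available to explain these results.

Still open, as far as these compounds go, is how a simple phenyl or a non-aromatic cyclohexyl would read on this carbonyl carbon. From the compounds shown here alone, the effect of a carboxylic acid or an amine on the quinolin-8-yl also remains open.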